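From 4-fluorophenyl to furan-2-yl on a carbonyl carbon

A few compounds are considered here, and "the series" means these few. Any claim that something is new, unique, unknown or untested is made for them only; others in the source may bear on it.

Compound 1 `COc1ccc(S(=O)(=O)N2CCc3cccc(NC(=O)Oc4ccccc4)c32)cc1` with > 10000 nM (a limit)
Compound 2 `COc1ccc(S(=O)(=O)N2CCc3cccc(NC(=O)c4ccc(F)cc4)c32)cc1` with 45 nM

Among the measured compounds shown here, in a functional assay on MKN-45 cells (Homo sapiens) for cytotoxicity (a lower number here means a stronger inhibitor, a higher number a weaker inhibitor), compound 2 gives 45 nM as the only number so far. Compound 1 stands at > 10000 nM as a limit and not a number. Compound 3 `COc1ccc(S(=O)(=O)N2CCc3cccc(NC(=O)c4ccco4)c32)cc1` is still unmeasured and departs from compound 2 in one place, with furan-2-yl in place of 4-fluorophenyl on a carbonyl carbon is what changes.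

For the measured compounds named here, the one measured step at that carbonyl carbon is an at least 220-fold lower number from compound 1 to compound 2 (2.34 log units; beyond the scatter) and it is large. That step removes phenoxy, however, and compound 3 has no phenoxy in that place. Compound 3 keeps an aromatic ring on the carbonyl carbon, as does compound 2 at 45 nM and so the size of the earlier step is not expected to carry over. No step beyond the scatter is expected in this assay and no clear direction either. The estimated change is a 1.1-fold lower number from compound 2 to compound 3 (0.05 log units; within the scatter) as an expectation only. For compound 3 the expected value is 40 nM with an estimated range from 12 nM to 140 nM.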

Compound 3, half-maximal inhibitory concentration: 10.7 nM
Compound 3: middle estimate off by 3.7-fold (0.57 log units), on the high side; the measured number lies below the stated range.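

In this assay, furan-2-yl in place of 4-fluorophenyl on the carbonyl carbon gives a 4.2-fold lower number from compound 2 to compound 3 (0.62 log units; beyond the scatter), so this position separates one aromatic ring from another and not only an aromatic ring from phenoxy. Furan-2-yl in place of phenoxy at the same carbon gives an at least 930-fold lower number from compound 1 to compound 3 (2.97 log units; beyond the scatter), which adds a second ring to the one earlier comparison with phenoxy. Compound 1 stands at a limit and not a number, and both steps from it carry that limit: the limit of > 10000 nM in this assay, at which 1 of the 3 values shown sits.

The compounds shown leave open which part of the change from 4-fluorophenyl to furan-2-yl goes with the step: the loss of the fluorine, the smaller ring or the ring oxygen, which a plain phenyl or a thiophen-2-yl on the same carbonyl carbon would begin to separate. They also leave open whether an aromatic ring is needed at this carbon at all, a question that a cyclohexyl, a tetrahydrofuran-2-yl or a short alkyl chain there would address.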